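The source may report more compounds than this note shows. Statements on the series, on what has been measured and on what is new or still open speak of the compounds shown alone.

In a functional assay on CCRF-CEM cells (Homo sapiens) for antiproliferative activity, read by cell counting, with a stated time of 96 h (on this read-out lower numbers stand for stronger inhibition and higher numbers for weaker inhibition), compound 1 `CC(=O)c1ccc(Oc2ccccc2NC(C)=C2C(=O)CC(c3ccccc3)CC2=O)cc1` gives 220 nM and compound 2 `COc1ccc(Oc2ccccc2NC(C)=C2C(=O)CC(c3ccccc3)CC2=O)cc1OC` gives 160 nM. Among the measured compounds shown here, these two numbers lie within the usual scatter of each other, so compound 2 stands level with the only other compound measured so far. Compound 3 `CC(Nc1ccccc1Oc1ccccc1)=C1C(=O)CC(c2ccccc2)CC1=O` keeps the shared core and changes one group: phenyl in place of 3,4-dimethoxyphenyl on an oxygen on an aromatic ring. In words, this is phenyl in place of 3,4-dimethoxyphenyl on an oxygen on an aromatic ring. For the measured compounds named here, one measured step bears on this change, since it swaps a group at the same place: a 1.4-fold lower number from compound 1 to compound 2 (0.14 log units; within the scatter). That step stays within the scatter, even though 4-acetylphenyl and 3,4-dimethoxyphenyl are quite different groups. Going by the values given here, a single step is thin evidence, however, and no measured compound yet carries plain phenyl at this place. No change beyond the scatter is therefore expected in this assay, in either direction. The estimate amounts to an expected 1.3-fold higher number from compound 2 to compound 3 (0.10 log units; within the scatter). For compound 3 the estimated value is 200 nM, with an expected range from 80 nM to 500 nM.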

Compound 3, half-maximal inhibitory concentration: 170 nM
The estimate for compound 3 lay 1.2-fold (0.07 log units) above the measured number, and the stated range covers the measured number.
By their numbers in this assay, from the lowest: compounds 2, 3 and 1 (each within the scatter of the next).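

In this assay, among the compounds shown here, compound 3 gives the first reading with plain phenyl on this oxygen, and removing both methoxy groups leaves the result level: a 1.1-fold higher number from compound 2 to compound 3 (0.03 log units; within the scatter). The same plain ring also stands level with the acetyl-bearing ring, with a 1.3-fold lower number from compound 1 to compound 3 (0.11 log units; within the scatter), so this comparison isolates the acetyl group in a way the earlier pair could not. Across these three compounds, then, neither the acetyl group nor the two methoxy groups moves the number beyond the scatter compared with the unsubstituted ring, although nothing available explains this flat result.

As far as these compounds go, all three compounds keep an aromatic ring on this oxygen and carry only neutral groups on it, so the effect of an amine or a carboxylic acid on that ring, or of a longer alkyl chain in place of the ring, remains open. From the compounds shown here alone, it is also open whether this flatness would persist with changes elsewhere on the shared core, which stays the same in all three compounds.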